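Solubility notes: the amine substituent on the shared core

A few compounds are considered here, and "the series" means these few. Any claim that something is new, unique, unknown or untested is made for them only; others in the source may bear on it.

The series keeps one core and differs only at the amine nitrogen on the ring. Compound 1 `Cc1cc(NCc2cccnc2)n2nc(C)c(-c3ccccc3)c2n1` carries a (pyridin-3-yl)methyl there; in a physicochemical assay for solubility, read by HPLC, using the shake flask method, measured as kinetic solubility, with a stated time of 2 h, at pH 7.4 (a higher number here means a more soluble compound, a lower number a less soluble compound), compound 1 gives 110000 nM. Compound 2 `Cc1cc(NCCCc2ccccn2)n2nc(C)c(-c3ccccc3)c2n1` carries a 3-(pyridin-2-yl)propyl, and in this assay compound 2 gives 5900 nM. Compound 3 `Cc1cc(Nc2ccccn2)n2nc(C)c(-c3ccccc3)c2n1` carries pyridin-2-yl directly on the nitrogen. In this assay compound 3 gives only a limit, < 5000 nM, so its exact standing is open. That limit is the floor (the limit of < 5000 nM in this assay, at which 1 of the 3 values shown sits). The step of a 19-fold lower number from compound 1 to compound 2 (1.27 log units; beyond the scatter) and the step of an at least 22-fold lower number from compound 1 to compound 3 (1.34 log units; beyond the scatter) both lower the number sharply, while the step of an at least 1.1-fold lower number from compound 2 to compound 3 (0.07 log units; that floor lies within the scatter) stays within the scatter at that floor.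

Compound 4 `Cc1cc(NCc2nccn2C)n2nc(C)c(-c3ccccc3)c2n1` makes the change ((1-methyl-1H-imidazol-2-yl)methyl in place of pyridin-2-yl on a nitrogen on an aromatic ring). For the measured compounds named here, it restores a one-carbon link between the nitrogen and the aromatic ring, as in compound 1, whose 110000 nM is the highest number in the set; the move to a five-membered ring with two hetero atoms has no measured counterpart here. The step of an at least 12-fold higher number from compound 3 to compound 4 (1.07 log units; beyond the scatter) is therefore expected to be large and upward, with wide uncertainty. Compound 4 is estimated at 60000 nM, within 12000 nM to 200000 nM.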

Compound 4, solubility: 26900 nM
Beside the measured number, compound 4's estimate is 2.2-fold (0.35 log units) above it; low and high end bracket the measured number.
By their numbers in this assay, from the lowest: compound 2; then compound 4; then compound 1. At a limit, below all of these: compound 3.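

On this nitrogen, a second aromatic ring carried on a methyl link does not depend on pyridin-3-yl to give a high number in this assay: with 1-methyl-1H-imidazol-2-yl in place of pyridin-3-yl there is a 4.1-fold lower number from compound 1 to compound 4 (0.61 log units; beyond the scatter), so the ring on that link still matters, but compound 4 stays well above the other two compounds. The 3-(pyridin-2-yl)propyl compound falls short of it, with a 4.6-fold higher number from compound 2 to compound 4 (0.66 log units; beyond the scatter), so in these four compounds both groups with a methyl link, in compound 1 and compound 4, give higher numbers than the propyl chain and the directly attached pyridin-2-yl, and none of the four goes against this. From the directly attached ring the step is an at least 5.3-fold higher number from compound 3 to compound 4 (0.73 log units; beyond the scatter), but compound 3 stands at a limit, so this step is a floor and its true size stays open: the limit of < 5000 nM in this assay, at which 1 of the 4 values shown sits.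

These compounds change the ring and the link together, so the share of each in the steps remains unresolved. A (pyridin-2-yl)methyl or a benzyl on the same nitrogen would separate the link from the ring, and a 2-(pyridin-2-yl)ethyl would show how the number runs with chain length.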